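A few compounds are considered here, and "the series" means these few. Any claim that something is new, unique, unknown or untested is made for them only; others in the source may bear on it.

Compound 3 `N#Cc1cccc(C(=O)Nc2c(C(O)(C(F)(F)F)C(F)(F)F)ccc3ccccc23)c1` carries a 3-cyanophenyl group on the carbonyl carbon of the shared core. Within the data shown here, in a functional assay (Sus scrofa) with sulfonylurea receptors; K-ATP channels (Homo sapiens) as the target (a lower number here means that less compound is needed, a higher number that more compound is needed for the effect), compound 3 gives 372 nM, the highest of the three numbers measured so far. The two comparison compounds keep the same core but carry small rings on that carbonyl carbon: compound 1 `O=C(Nc1c(C(O)(C(F)(F)F)C(F)(F)F)ccc2ccccc12)C1CC1` gives 126 nM in this assay, and compound 2 `O=C(Nc1c(C(O)(C(F)(F)F)C(F)(F)F)ccc2ccccc12)C1CCC1` gives 81.3 nM. The step of a 1.5-fold lower number from compound 1 to compound 2 (0.19 log units; within the scatter) is small, whereas a 3.0-fold higher number from compound 1 to compound 3 (0.47 log units; beyond the scatter) and a 4.6-fold higher number from compound 2 to compound 3 (0.66 log units; beyond the scatter) both go beyond the scatter, so the aromatic ring bearing a nitrile on the carbonyl carbon went with a higher number than either small ring.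

Compound 4 `O=C(Nc1c(C(O)(C(F)(F)F)C(F)(F)F)ccc2ccccc12)c1cccc([N+](=O)[O-])c1` differs from compound 3 in one place: nitro in place of cyano on an aromatic carbon. Among the measured compounds shown here, none of the measured steps bears directly on this kind of change; all three concern what sits on the carbonyl carbon, and no pair among compounds 1, 2 and 3 swaps one group for another on the aromatic ring. Compound 4 keeps the aromatic ring on the carbonyl carbon, so compound 4 is expected to give 350 nM in this assay, with a range from 150 nM to 800 nM. That estimate means a step of a 1.1-fold lower number from compound 3 to compound 4 (0.03 log units; within the scatter) that is expected to stay within the scatter.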

Compound 4, half-maximal effective concentration: 427 nM
Beside the measured number, compound 4's estimate is 1.2-fold (0.09 log units) below it, within the range that was stated.
By their numbers in this assay, from the lowest: compounds 2 and 1 (each within the scatter of the next); then compounds 3 and 4 (each within the scatter of the next).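

In this assay, among these compounds, the step of a 1.1-fold higher number from compound 3 to compound 4 (0.06 log units; within the scatter) is the first look at a change on the aromatic ring itself rather than on the carbonyl carbon: at this place, meta to a large group, nitro with its 3 heavy atoms and 2 hydrogen-bond acceptors reads the same as cyano with its 2 heavy atoms and 1 acceptor. The gap to the small rings also holds for a second aromatic group, since both a 5.3-fold higher number from compound 2 to compound 4 (0.72 log units; beyond the scatter) and a 3.4-fold higher number from compound 1 to compound 4 (0.53 log units; beyond the scatter) go beyond the scatter, so the higher number no longer rests on 3-cyanophenyl alone. Nothing measured here explains why these two groups read alike or why both aromatic compounds sit above the small rings.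

Among the compounds shown here, with only one swap on the aromatic ring, it remains open whether an amine or a carboxylic acid at the same carbon would also stay close to compound 3 and compound 4. Going by these compounds, it is equally open whether an unsubstituted phenyl or a longer chain on the carbonyl carbon would fall with the aromatic pair or with the small rings.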